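From Thioester to a Bulkier Ester at the Carbonyl Carbon

The compounds below may be only part of what the source reports. "The series", "measured", "known", "first", "only" and "open" are said of these compounds alone.

Of the compounds shown here, three sharing one core have been measured in an assay on membranes from HEK293 cells for displacement of a labelled ligand from adenosine receptor A2b (Homo sapiens), read by scintillation counting, with a stated time of 30 min, tested at 1 uM; a higher number here means more inhibition at the concentration tested (going by the name of the read-out), a lower number less inhibition. Compound 1 `COC(=O)C1=C(C)NC(=O)NC1c1cccs1` gives 19%, compound 2 `CCCC(=O)C1=C(C)NC(=O)NC1c1cccs1` gives 9%, and compound 3 `CC1=C(C(=O)SC(C)C)C(c2cccs2)NC(=O)N1` gives 1%. Compound 3 stands lowest of the three numbers: the step of a number 18 percentage points lower from compound 1 to compound 3 (beyond the scatter) is beyond the scatter, whereas a number 10 percentage points lower from compound 1 to compound 2 (within the scatter) and a number 8 percentage points lower from compound 2 to compound 3 (within the scatter) are within it. Compound 4 `CCC(CC)OC(=O)C1=C(C)NC(=O)NC1c1cccs1` is not yet measured. It differs from compound 3 in one place: (pentan-3-yl)oxy in place of isopropylsulfanyl on a carbonyl carbon. This returns to an ester, as in compound 1, though with (pentan-3-yl)oxy rather than methoxy. Because the step of a number 18 percentage points lower from compound 1 to compound 3 (beyond the scatter) ran downward on going from ester to thioester, a modest rise in the reverse direction is expected, estimated as a number 9 percentage points higher from compound 3 to compound 4 (within the scatter). Compound 4 is therefore expected to give about 10%, with a range from 0% to 25%.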

Compound 4, a percentage reported as inhibition, at one concentration (the size of the read-out at that concentration, not a potency): 6%
Compound 4: the middle estimate sits 4 percentage points above what was measured, within the range that was stated.
By their numbers in this assay, from the lowest: compounds 3, 4, 2 and 1 (each within the scatter of the next, the first and the last beyond it).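

In this assay, the replacement of isopropylsulfanyl or propyl by (pentan-3-yl)oxy gives a number 5 percentage points higher from compound 3 to compound 4 (within the scatter) and a number 3 percentage points lower from compound 2 to compound 4 (within the scatter), so on this carbonyl carbon the new group cannot be told apart from either. Returning to an ester does not by itself restore the value of compound 1: pentan-3-yl in place of methyl on the oxygen gives a number 13 percentage points lower from compound 1 to compound 4 (beyond the scatter). No available evidence accounts for this result. From the compounds shown here alone, whether an amine or a carboxylic acid on this carbonyl carbon would give a clearly higher number remains open.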